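The source may report more compounds than this note shows. Statements on the series, on what has been measured and on what is new or still open speak of the compounds shown alone.

Three members of this series have been tested in a functional assay on MCF7 cells (Homo sapiens) for inhibition, read by sulforhodamine B assay, with a stated time of 24 h; on this read-out higher numbers stand for weaker inhibition and lower numbers for stronger inhibition. Compound 1 `N#Cc1c(-c2ccccc2)cn(-c2ccc(S(=O)(=O)Nc3ccccn3)cc2)c1NC(N)=O` gives 7340 nM, compound 2 `CC(=O)Nc1c(C#N)c(-c2ccccc2)cn1-c1ccc(S(=O)(=O)Nc2ccccn2)cc1` gives 11800 nM, and compound 3 `N#Cc1c(-c2ccccc2)cn(-c2ccc(S(=O)(=O)Nc3nccs3)cc2)c1NC(=O)CCC(=O)O` gives 9120 nM. The three values sit close together: compound 3 stands second highest of the three, nearest to compound 1 and furthest from compound 2, yet both gaps fall within the scatter. Within the data shown here, the one single-point step among the measured compounds is a 1.6-fold higher number from compound 1 to compound 2 (0.21 log units; within the scatter), which concerns the acyl group rather than the sulfonamide substituent.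

Compound 4 `N#Cc1c(-c2ccccc2)cn(-c2ccc(S(=O)(=O)Nc3ccccn3)cc2)c1NC(=O)CCC(=O)O` differs from compound 3 in one place: pyridin-2-yl in place of 1,3-thiazol-2-yl on a sulfonamide nitrogen. Among the measured compounds shown here, no measured pair isolates this exchange, since compounds 1 and 2 carry the pyridin-2-yl group together with other acyl groups, while compound 3 alone carries the 1,3-thiazol-2-yl group. All that can be said is that every change seen so far in this set has left this assay essentially unmoved, with all three numbers within the scatter of one another. On that basis the step is expected to be a 1.1-fold lower number from compound 3 to compound 4 (0.03 log units; within the scatter), without a clear direction beyond the scatter. Compound 4 is therefore estimated at 8500 nM, with a range from 3500 nM to 20000 nM.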

Compound 4, half-maximal inhibitory concentration: 8320 nM
Compound 4: middle estimate off by 1.0-fold (0.01 log units), on the high side; the measured number falls inside the stated range.
By their numbers in this assay, from the lowest: compounds 1, 4, 3 and 2 (each within the scatter of the next).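

In this assay, the exchange on the sulfonamide nitrogen can now be read on its own, with the rest of the molecule held constant: pyridin-2-yl in place of 1,3-thiazol-2-yl gives a 1.1-fold lower number from compound 3 to compound 4 (0.04 log units; within the scatter), so this read-out does not tell the six-membered ring from the five-membered ring at this position. With pyridin-2-yl held constant, the acyl group can also be compared across a third member, as carboxymethyl in place of hydrogen on the saturated chain carbon gives a 1.4-fold lower number from compound 2 to compound 4 (0.15 log units; within the scatter) and 2-carboxyethyl in place of amino on the carbonyl carbon gives a 1.1-fold higher number from compound 1 to compound 4 (0.05 log units; within the scatter), so the carboxylic acid chain cannot be told apart from either shorter acyl group. Nothing measured alongside these numbers offers an explanation for them.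

From the compounds shown here alone, both groups on the sulfonamide nitrogen are aromatic rings, so it remains open whether a pyrimidin-2-yl group, a plain phenyl or a methyl there would give a step beyond the scatter. Going by these compounds, it is equally open whether a longer chain, an ester or an amine at the end of the acyl group would separate from these compounds.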